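The source may report more compounds than this note shows. Statements on the series, on what has been measured and on what is new or still open speak of the compounds shown alone.

Compound 1 `CN1C[C@H](NC(=O)OCCCCC2CCCCC2)C1=O` and compound 2 `CCCCCCCON1C(=O)[C@@H](NC(=O)OCCCCC2CCCCC2)[C@@H]1C` share a core carrying the same carbamate side chain. In an assay on HEK293 cells for inhibition of N-acylethanolamine-hydrolyzing acid amidase (Homo sapiens), read by fluorescence, with stated times of 10 min and 50 min (a lower number here means a stronger inhibitor, a higher number a weaker inhibitor), compound 1 gives 1980 nM, and in this assay compound 2 gives 2230 nM; these two numbers sit within the scatter of each other, so neither compound is set apart from the other. Compound 3 `C[C@H]1[C@H](NC(=O)OCCCCC2CCCCC2)C(=O)N1OCCCCC1CCCCC1` has not yet been measured. Its change from compound 2 is cyclohexyl in place of propyl on a saturated chain carbon, four bonds along the chain from an oxygen on an unsaturated carbon. Within the data shown here, no measured pair tests this change, so the step is expected to be small, a 1.5-fold lower number from compound 2 to compound 3 (0.17 log units; within the scatter), with no direction beyond the scatter. Compound 3 is therefore estimated at 1500 nM, in a range from 500 nM to 5000 nM.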

Compound 3, half-maximal inhibitory concentration: 3470 nM
Compound 3: middle estimate off by 2.3-fold (0.36 log units), on the low side; the measured number falls inside the stated range.
By their numbers in this assay, from the lowest: compounds 1, 2 and 3 (each within the scatter of the next).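

In this assay, cyclohexyl in place of propyl on a saturated chain carbon, four bonds along the chain from an oxygen on an unsaturated carbon, gives a 1.6-fold higher number from compound 2 to compound 3 (0.19 log units; within the scatter), so this position accepts a ring in place of the open propyl end with no step beyond the scatter. Nothing available explains this result.

Still open, from the compounds shown here alone, is whether any group at this position would move the number beyond the scatter. An amine, a carboxylic acid or a longer chain in place of cyclohexyl would test this.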